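The source may hold more compounds than are shown below. What is called first, only, known or untested is meant among the compounds shown, and "the series" means these compounds.

Measured compounds in the series:
- compound 1 `CC(C)(C)c1ccc(Oc2ccc3c(NCCCNCc4ccco4)ccnc3c2)cc1`: 3100 nM
- compound 2 `Cc1cc(C)cc(Cc2ccc3c(NCCCNCc4ccco4)ccnc3c2)c1`: 6270 nM
- compound 3 `c1ccc(CCc2ccc3c(NCCCNCc4ccco4)ccnc3c2)cc1`: 16000 nM

In an ADME assay on HepG2 cells (Homo sapiens) for cytotoxicity, read by luminescence, CellTiter-Glo and ATP content, with a stated time of 72 h (a higher number here means that more compound is needed for the effect, a lower number that less compound is needed), compound 3 gives 16000 nM, the highest of the three numbers. Compound 2 gives 6270 nM and compound 1 gives 3100 nM; both steps from compound 3 to these, measured and computed, are beyond the scatter, so compound 3 is the compound of the three that needs the most material for the effect.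

Compound 4 `COc1cccc(Oc2ccc3c(NCCCNCc4ccco4)ccnc3c2)c1` is next. Compared with compound 3 the change is 3-methoxyphenoxy in place of phenethyl on an aromatic carbon. Among the measured compounds shown here, only one step within the measured set is a single-point change, a 2.6-fold higher number from compound 2 to compound 3 (0.41 log units; beyond the scatter), and it concerns an exchange on a saturated chain carbon rather than on the aromatic carbon that changes here, so it bears on the present step only loosely; it does show that a swap of the pendant aryl group can move this assay beyond the scatter. For the measured compounds named here, no measured step links compound 1 and compound 3; their two values simply show compound 1 with the lower number. On that basis the step from compound 3 to compound 4 is expected to bring a modest decrease, a 3.2-fold lower number from compound 3 to compound 4 (0.51 log units; beyond the scatter). Compound 4 is therefore estimated at 5000 nM, with a range from 2000 nM to 13000 nM.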

Compound 4, half-maximal effective concentration: 15500 nM
Beside the measured number, compound 4's estimate is 3.1-fold (0.49 log units) below it; measured number above the stated range.
By their numbers in this assay, from the lowest: compound 1; then compound 2; then compounds 4 and 3 (each within the scatter of the next).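

Working notes on the series: in this assay the exchange of phenethyl for 3-methoxyphenoxy on this aromatic carbon gives a 1.0-fold lower number from compound 3 to compound 4 (0.01 log units; within the scatter), so the assay does not separate these two groups, although the entering group carries 2 hydrogen-bond acceptors and the leaving group carries 0. The same entering group does separate from 3,5-dimethylbenzyl, with a 2.5-fold higher number from compound 2 to compound 4 (0.39 log units; beyond the scatter), so exchanges at this position do not all fall within the scatter. With the oxygen on the aromatic ring kept in place, the exchange of 4-(tert-butyl)phenyl for 3-methoxyphenyl gives a 5.0-fold higher number from compound 1 to compound 4 (0.70 log units; beyond the scatter), which shows that a change on the pendant ring alone can move the number beyond the scatter.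

No available evidence accounts for any of these steps. The compounds shown leave open how an unsubstituted phenoxy, or a pendant ring bearing an amine or a carboxylic acid, would behave at this position, and with only these few groups no trend across the pendant ring can yet be stated.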